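The source may report more compounds than this note shows. Statements on the series, on what has been measured and on what is new or still open speak of the compounds shown alone.

Measured so far in a functional assay on A2780 cells (Homo sapiens) for inhibition, read by sulforhodamine B assay, with a stated time of 72 h; on this read-out lower numbers stand for stronger inhibition and higher numbers for weaker inhibition:

Compound 1, `O=C(NCc1ccc(S(=O)(=O)c2ccccc2)cc1)c1cc(-c2cccnc2)[nH]n1`, gives > 10000 nM, a limit of the assay rather than a number.
Compound 2, `O=C(NCc1ccc(S(=O)(=O)c2ccccc2)cc1)c1cc2ncccc2s1`, gives > 10000 nM, again a limit.
Compound 3, `CC(NC(=O)c1cc2cnccc2[nH]1)c1ccc(S(=O)(=O)N2CCCCC2)cc1`, gives > 10000 nM, also a limit.

Among the measured compounds shown here, compound 2 therefore stands only at the edge of what this assay can report, and every value so far sits at the same edge (the limit of > 10000 nM in this assay, at which 3 of the 3 values shown sit). For the measured compounds named here, no measured pair differs in a single place, so no measured step can show how a change in the group on the carbonyl carbon moves the read-out.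

Compound 4, `O=C(NCc1ccc(S(=O)(=O)c2ccccc2)cc1)c1cc2cnccc2[nH]1`, differs from compound 2 in one place: a group of 9 heavy atoms (7 carbon, 2 nitrogen; one five-membered aromatic ring with 1 hetero atom, one six-membered aromatic ring with 1 hetero atom) in place of a group of 9 heavy atoms (7 carbon, 1 nitrogen, 1 sulfur; one five-membered aromatic ring with 1 hetero atom, one six-membered aromatic ring with 1 hetero atom), on a carbonyl carbon

The group that enters is the same bicyclic group that compound 3 carries on its carbonyl carbon, and compound 3 gives only a limit in this assay. On that basis the step from compound 2 to compound 4 is expected to be none beyond the scatter, a step that the limit leaves unreadable from compound 2 to compound 4, with the result most likely reported again as a limit. Compound 4 is expected at 15000 nM, within a range from 5000 nM to 50000 nM.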

Compound 4, half-maximal inhibitory concentration: 18 nM
Estimate against measurement, compound 4: 830-fold (2.92 log units) above; the whole stated range lies above it.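

In this assay compound 2 gives > 10000 nM, which is a limit of the assay and not a number. Exchanging only the group on the carbonyl carbon, with the rest of the molecule unchanged, gives an at least 550-fold lower number from compound 2 to compound 4 (2.74 log units; beyond the scatter), so this position alone can take the read-out from the edge of the assay to a measurable value. Compound 4 is the only compound shown that gives a measurable value, and the others remain at the edge: the limit of > 10000 nM in this assay, at which 3 of the 4 values shown sit.

The two groups differ in more than one way, with sulfur against a second nitrogen and a hydrogen-bond donor absent or present, so this single step cannot tell which difference counts. Also open, from the compounds shown here alone, is how compound 4 would read if a methyl group replaced the hydrogen that makes up its donor.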